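Methylsulfonyl for carboxy in a leukotriene receptor antagonist series

The compounds below may be only part of what the source reports. "The series", "measured", "known", "first", "only" and "open" are said of these compounds alone.

Compound 1, `CCC(CSC(CCc1ccccc1C(=O)O)c1cccc(OCc2ccc3ccc(Cl)cc3n2)c1)C(=O)O`, is the reference point of this small set. For the measured compounds named here, in an assay on membranes from lung for binding affinity to cysteinyl leukotriene receptor 1 (Cavia porcellus) (a higher number here means a weaker inhibitor, a lower number a stronger inhibitor), compound 1 gives 2 nM, the highest of the two numbers so far; its only measured neighbour is compound 2, `CCC(CSC(CCc1ccccc1C(=O)NS(=O)(=O)c1ccccc1C)c1cccc(OCc2ccc3ccc(Cl)cc3n2)c1)C(=O)O`, which in this assay gives 1.4 nM, and the step of a 1.4-fold lower number from compound 1 to compound 2 (0.15 log units; within the scatter) stays within the scatter. The unmeasured compound 3, `CCC(CSC(CCc1ccccc1S(C)(=O)=O)c1cccc(OCc2ccc3ccc(Cl)cc3n2)c1)C(=O)O`, differs from compound 1 by methylsulfonyl in place of carboxy on an aromatic carbon. Going by the values given here, the one measured step bears on it only loosely: the change from compound 1 to compound 2 altered the same carboxy group and left the number essentially unchanged, which shows that this position tolerates at least one modification. Among the compounds with values here, compound 3, however, loses the carboxy group altogether rather than exchanging it, and no measured step shows what that costs. The expectation is therefore a modest weakening, a 3.0-fold higher number from compound 1 to compound 3 (0.48 log units; beyond the scatter), with wide uncertainty. Compound 3 is estimated at 6 nM in this assay, with a range from 1.5 nM to 30 nM.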

Compound 3, half-maximal inhibitory concentration: 0.6 nM
For compound 3 the middle estimate is 10-fold (1.00 log units) above the measured one; the whole stated range lies above it.
By their numbers in this assay, from the lowest: compound 3; then compounds 2 and 1 (each within the scatter of the next).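

In this assay, methylsulfonyl in place of carboxy on this aromatic carbon gives a 3.3-fold lower number from compound 1 to compound 3 (0.52 log units; beyond the scatter), so an affinity in the low range of this set does not depend on a carboxy group at this place. For the compounds shown here, the earlier step, a 1.4-fold lower number from compound 1 to compound 2 (0.15 log units; within the scatter), showed only that this carboxy group could be extended while its carbonyl stayed, and it left the number within the scatter; compound 3 has no carbonyl here at all, its entering group has no hydrogen-bond donor, and its step is the first at this position to lie beyond the scatter. The data shown offer no independent measurement that explains why this exchange lowers the number.

The compounds shown leave open whether the sulfonyl group itself contributes, since a plain hydrogen or a methyl on this aromatic carbon would separate the effect of the sulfonyl from that of simply losing the carboxy group. They also leave open how far the methyl of the sulfone can be changed, for instance to an ethyl, a phenyl or an amine giving a sulfonamide.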